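From Carboxy to Carbamoyl on a Shared Core

The source may report more compounds than this note shows. Statements on the series, on what has been measured and on what is new or still open speak of the compounds shown alone.

Of the compounds shown here, two have so far been measured in an ADME assay on Vero cells (Chlorocebus sabaeus) for cytotoxicity, read by MTT assay, with a stated time of 72 h (on this read-out lower numbers stand for stronger inhibition and higher numbers for weaker inhibition), and they sit far apart. Compound 2 (`Cc1csc(-c2ccnc(Nc3ccc(C(=O)O)cc3)n2)c1`) gives 80800 nM as the higher of the two numbers. Compound 1 (`COc1ccc(-c2ccnc(Nc3ccc(C(N)=O)cc3)n2)cc1`) gives 5400 nM as the lower number, and the gap between the pair lies beyond the scatter of repeated measurements. Among the measured compounds shown here, these two compounds differ in more than one place, so no measured pair isolates a single change.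

Compound 3 (`Cc1csc(-c2ccnc(Nc3ccc(C(N)=O)cc3)n2)c1`) keeps the rest of compound 2 and alters one place, with amino in place of hydroxy on a carbonyl carbon turning carboxy into carbamoyl. For the measured compounds named here, the expectation rests on compound 1 at 5400 nM as the only measured compound that carries carbamoyl, although its core differs. A move toward a lower number is therefore expected. The expected change is a 9.0-fold lower number from compound 2 to compound 3 (0.95 log units; beyond the scatter) in this assay and would lie beyond the scatter. Compound 3 is estimated at 9000 nM with a range from 3000 nM to 27000 nM until a measurement is available.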

Compound 3, half-maximal inhibitory concentration: 6200 nM
The estimate for compound 3 lay 1.5-fold (0.16 log units) above the measured number; low and high end bracket the measured number.
By their numbers in this assay, from the lowest: compounds 1 and 3 (each within the scatter of the next); then compound 2.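

In this assay, among the compounds shown here, amino in place of hydroxy on a carbonyl carbon, with everything else held fixed, gives a 13-fold lower number from compound 2 to compound 3 (1.12 log units; beyond the scatter) and so provides the first measured pair that isolates the change from carboxy to carbamoyl. For the compounds shown here, with carbamoyl in place, 4-methylthiophen-2-yl in place of 4-methoxyphenyl on an aromatic carbon gives a 1.1-fold higher number from compound 1 to compound 3 (0.06 log units; within the scatter) and thus does not separate these two groups in this assay, leaving the change on the carbonyl carbon as the only one of the two steps that lies beyond the scatter. Nothing available here bears on the reason for the large step, which therefore stands as an observation on a single pair of compounds.

The compounds shown leave open where other groups on that carbonyl carbon, such as methoxy in a methyl ester or methylamino in an N-methyl amide, would fall relative to hydroxy and amino. They also leave open whether amino in place of hydroxy would give a step of similar size with 4-methoxyphenyl on the aromatic carbon instead of 4-methylthiophen-2-yl.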